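The compounds below may be only part of what the source reports. "The series", "measured", "known", "first", "only" and "open" are said of these compounds alone.

In a functional assay on K562 cells (Homo sapiens) for cytotoxicity, read by MTT assay, with a stated time of 72 h (a higher number here means a weaker inhibitor, a lower number a stronger inhibitor), compound 1 `C=C1C(=O)[C@@]23C(=O)OC[C@]4([C@@H](OC(C)=O)CCC(C)(C)[C@H]4C=O)[C@@H]2CC[C@@H]1[C@H]3O` gives 9560 nM, compound 2 `C=C1C(=O)[C@@]23C(=O)OC[C@]4(C(=O)CCC(C)(C)[C@H]4C=O)[C@@H]2CC[C@@H]1[C@H]3OC(=O)c1ccc(C)cc1` gives 1270 nM and compound 3 `C=C1C(=O)[C@@]23C(=O)OC[C@]4(C(=O)CCC(C)(C)[C@H]4C=O)[C@@H]2CC[C@@H]1[C@H]3OC(=O)c1ccc(OC)cc1` gives 1650 nM. Compound 2 thus stands level with compound 3 within the scatter, and both numbers lie well under that of compound 1. Compound 4 `C=C1C(=O)[C@@]23C(=O)OC[C@]4(C(=O)CCC(C)(C)[C@H]4C=O)[C@@H]2CC[C@@H]1[C@H]3OC(=O)c1ccc(F)cc1` differs from compound 2 by fluoro in place of methyl on an aromatic carbon, para to a large group. Going by the values given here, one measured step bears on this change, a 1.3-fold higher number from compound 2 to compound 3 (0.11 log units; within the scatter), where methoxy replaces the same methyl. Among the compounds with values here, no fluoro compound has been measured, so no direction is favoured. The expected step is a 1.1-fold higher number from compound 2 to compound 4 (0.04 log units; within the scatter), not beyond the scatter. For compound 4 the estimated value is 1400 nM, with an expected range of 700 nM to 2800 nM.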

Compound 4, half-maximal inhibitory concentration: 2700 nM
Beside the measured number, compound 4's estimate is 1.9-fold (0.29 log units) below it, within the range that was stated.
By their numbers in this assay, from the lowest: compounds 2, 3 and 4 (each within the scatter of the next, the first and the last beyond it); then compound 1.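

Going by these compounds alone, on the aromatic carbon para to a large group, the change in this assay from methyl to fluoro gives a 2.1-fold higher number from compound 2 to compound 4 (0.33 log units; beyond the scatter) and is the first step at this position to pass the scatter, though only modestly. Fluoro in place of methoxy gives a 1.6-fold higher number from compound 3 to compound 4 (0.21 log units; within the scatter) and so does not separate these two groups. No measurement at hand accounts for either step.

From the compounds shown here alone, whether the modest rise is specific to fluoro remains open, since chloro and trifluoromethyl do not appear at this position. An amine or a carboxylic acid there also remains untested among the compounds shown.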